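This account rests on a few compounds, and the source may have more. Where it says the series, first, only, none or still open, it means among the compounds named here.

Three ureas built on the same core have so far been measured in a functional assay for antagonist activity at transient receptor potential cation channel subfamily V member 1 (Rattus norvegicus), read by FLIPR; on this read-out higher numbers stand for higher potency (the scale is a negative logarithm) and lower numbers for lower potency. Compound 1 `O=C(Nc1ccccc1Br)N[C@@H]1CCN(c2cccc(F)c2)C1` gives 7.8, the highest number of the three. Compound 2 `Cc1cccc2c1CCN2CCNC(=O)Nc1ccccc1Br` gives 7.4 in this assay, lower than compound 1 by more than the usual scatter, and compound 3 `O=C(Nc1ccccc1Br)N[C@@H]1CCN(c2cc(C(F)(F)F)ccn2)C1` gives 6.9, the lowest of the set. Compound 4 `N#Cc1ccc(N2CC[C@@H](NC(=O)Nc3ccccc3Br)C2)nc1` has not yet been measured. It differs from compound 1 in one place: 5-cyanopyridin-2-yl in place of 3-fluorophenyl on an amine nitrogen in a ring. Going by the values given here, no measured pair covers this exchange, so the direction rests on what the values show, in that compound 3, the nearest measured analogue, sits well below compound 1. A moderate loss is therefore expected, a number 0.50 log units lower from compound 1 to compound 4 (beyond the scatter). Compound 4 is estimated at 7.3, with a range from 6.6 to 8.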

Compound 4, negative logarithm of the antagonist equilibrium constant: 6.7
Compound 4: middle estimate off by 0.60 log units, on the high side; the measured number falls inside the stated range.
By their numbers in this assay, from the lowest: compounds 4 and 3 (each within the scatter of the next); then compound 2; then compound 1.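

In this assay, 5-cyanopyridin-2-yl in place of 3-fluorophenyl on the amine nitrogen in a ring gives a number 1.10 log units lower from compound 1 to compound 4 (beyond the scatter), a large step that gives this position its first single-change measurement. Compound 4 lies within the scatter of compound 3, which also carries a nitrogen-containing aromatic ring at this place. No measurement here accounts for the loss. On these data alone, it remains open whether the ring nitrogen or the nitrile goes with the loss. An unsubstituted pyridin-2-yl or a 3-cyanophenyl at this place would separate the two.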